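This account rests on a few compounds, and the source may have more. Where it says the series, first, only, none or still open, it means among the compounds named here.

Working notes on the series.

Compound 1, `CCCCCCCC/C=C\c1c(C)cc(C)nc1CCCOC`, carries a neutral core. In a functional assay on DU-145 cells (Homo sapiens) for antiproliferative activity, read by WST assay, with a stated time of 72 h (a higher number here means that more compound is needed for the effect, a lower number that less compound is needed), compound 1 gives > 30 uM, and this is a limit of the assay rather than a number, as recorded in the limit of > 30 uM in this assay, at which 1 of the 2 values shown sits. Going by the values given here, compound 2, `CCCCCCCC/C=C\c1c(C)c(/C=C/CCCCCCCC)c2[n+](c1C)CCC2`, is the only member with a measured number: in this assay compound 2 gives 0.2 uM. Among the compounds with values here, the one further value in the set is the limit belonging to compound 1. Within the data shown here, no step between two measured compounds that differ in one place exists, so no measured step sets the scale for what follows.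

Compound 3, `CCCCCCCC/C=C\c1c(C)c(/C=C/CCCCCCCC)c(C)[n+]2c1CCC2`, is the next to be measured. Relative to compound 2 the difference is the two compounds have the same atoms and bonds and differ only in configuration as drawn: 2 of 2 stereo elements differ; a double bond is drawn E in compound 2 and Z in compound 3; a double bond is drawn Z in compound 2 and E in compound 3. Nothing leaves and nothing enters; only the drawn configuration of the two double bonds is exchanged. Among the measured compounds shown here, with no measured step of this kind available, the expectation for this assay is a change of no more than the usual scatter in either direction, and the expected step of a 1.5-fold higher number from compound 2 to compound 3 (0.18 log units; within the scatter) reflects that. The estimate for compound 3 in this assay is 0.3 uM, with a range from 0.08 uM to 1.2 uM.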

Compound 3, concentration for half-maximal effect: 0.8 uM
The estimate for compound 3 lay 2.7-fold (0.43 log units) below the measured number; the range from low to high includes it.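

In this assay the series now has its first measured step, a 4.0-fold higher number from compound 2 to compound 3 (0.60 log units; beyond the scatter), and it shows that the number moves beyond the scatter with nothing leaving and nothing entering. The step can be assigned to configuration as drawn alone, because the atoms and bonds are shared: the fact that compounds 2 and 3 differ only in the configuration as drawn Both double bonds change together, so the step belongs to the paired exchange of E and Z and cannot be divided between the two double bonds.

Going by these compounds, what stays open is how much of the step belongs to each double bond, and whether the two exchanges reinforce or partly offset each other. Also open, on these data alone, is how the number in this assay would respond if a shorter chain, a saturated chain or a carboxylic acid took the place of either chain, since the two compounds compared here carry the same chains and differ only in how their double bonds are drawn.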